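A few compounds are considered here, and "the series" means these few. Any claim that something is new, unique, unknown or untested is made for them only; others in the source may bear on it.

Compound 1 `COc1ccccc1C1C(C(=O)C(C)(C)C)=C(O)C(=O)N1c1ccc(-c2ccon2)cc1` and compound 2 `CC(C)(C)C(=O)C1=C(O)C(=O)N(c2ccc(-c3ccon3)cc2)C1c1ccccc1OCCO` share one core, while compound 3 `COc1ccccc1C1C(C(=O)C(C)C)=C(O)C(=O)N1c1ccc(-c2ccsc2)cc1` and the not yet measured compound 4 `CC(C)C(=O)C1=C(O)C(=O)N(c2ccc(-c3ccsc3)cc2)C1c1ccccc1OCCO` share another; the difference between the two cores is not broken down here. In a physicochemical assay for solubility, in phosphate buffer, at pH 6.8 (on this read-out lower numbers stand for lower solubility and higher numbers for higher solubility), compound 1 gives 29600 nM. For compound 2 the read-out in this assay is a limit of the assay, > 50000 nM, and not a number. For compound 3 the read-out in this assay is likewise a limit of the assay, > 50000 nM.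

Among the measured compounds shown here, the one measured step is an at least 1.6-fold higher number from compound 1 to compound 2 (0.22 log units; that floor lies within the scatter), brought about by the change (hydroxymethyl in place of hydrogen on a saturated chain carbon bound to an oxygen on an aromatic ring). Its size can only be given as a floor because of the limit of > 50000 nM in this assay, at which 2 of the 3 values shown sit.

The same change, (hydroxymethyl in place of hydrogen on a saturated chain carbon bound to an oxygen on an aromatic ring), turns compound 3 into compound 4; the place is the same word for word in both cases, so this is the same kind of change on a different core. Compound 3 already sits at the limit, and the earlier step from compound 1 to compound 2 went in the direction of higher solubility, so compound 4 is expected to remain at or beyond that limit, with the step that the limit leaves unreadable from compound 3 to compound 4 being an estimate rather than a measurement. For compound 4 the expected value in this assay is 80000 nM, with an estimated range from 50000 nM to 250000 nM.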

Compound 4, solubility: > 50000 nM
Compound 4 was reported as a limit; the forecaster's own chance of this, stated with the estimate: 85%; the middle value does not contradict the limit.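

In this assay compound 4 gives > 50000 nM as a limit of the assay and not a number. Among the compounds shown here, no step from compound 3 to compound 4 can be read, because both values are limits: the limit of > 50000 nM in this assay, at which 3 of the 4 values shown sit. The compounds shown leave open how large the change from hydrogen to hydroxymethyl is on the core of compound 3, and whether it matches the step on the core of compound 1.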